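Swapping an aromatic ring for isopropoxy in EZH2 inhibitors

The source may report more compounds than this note shows. Statements on the series, on what has been measured and on what is new or still open speak of the compounds shown alone.

Measured compounds:
compound 1, `Cc1cc(C)c(CN2CCc3c(F)cc(O[C@@H]4CCOC4)c(Cl)c3C2=O)c(=O)[nH]1`: 260 nM
compound 2, `Cc1cc(C)c(CN2CCc3ccc(-c4c(C)noc4C)c(Cl)c3C2=O)c(=O)[nH]1`: 8.8 nM
compound 3, `Cc1cc(C)c(CN2CCc3c(C)cc(O[C@@H]4CCOC4)c(Cl)c3C2=O)c(=O)[nH]1`: 61 nM

All three were tested in an assay on Sf9 cells for inhibition of histone-lysine N-methyltransferase EZH2 variant Y641N (Homo sapiens), read by scintillation counting, with a stated time of 60 min, in the presence of a further agent that is not named here; a lower number here means a stronger inhibitor, a higher number a weaker inhibitor. Among them compound 2 gives the lowest number, 8.8 nM; compound 3 lies nearest with 61 nM, and compound 1 furthest with 260 nM, both gaps beyond the scatter. Going by the values given here, the one single-point step on record, a 4.3-fold lower number from compound 1 to compound 3 (0.63 log units; beyond the scatter), concerns a different place on the shared core and does not touch the group exchanged here.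

Compound 4, `Cc1cc(C)c(CN2CCc3ccc(OC(C)C)c(Cl)c3C2=O)c(=O)[nH]1`, has not yet been measured. It differs from compound 2 in one place: isopropoxy in place of 3,5-dimethyl-1,2-oxazol-4-yl on an aromatic carbon. Among the compounds with values here, no measured pair isolates this exchange. Compounds 1 and 3 carry a different oxygen-linked group at the same place but also differ from compound 2 elsewhere, so they give only a loose hint that an oxygen-linked group there tends to come with higher numbers than the 3,5-dimethyl-1,2-oxazol-4-yl group of compound 2. On that basis a moderate rise in this assay is expected, of about a 6.8-fold higher number from compound 2 to compound 4 (0.83 log units; beyond the scatter), with wide uncertainty. Compound 4 is therefore estimated at 60 nM, within a range of 15 nM to 250 nM.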

Compound 4, half-maximal inhibitory concentration: 160 nM
Beside the measured number, compound 4's estimate is 2.7-fold (0.43 log units) below it; measured number inside the range.
By their numbers in this assay, from the lowest: compound 2; then compound 3; then compounds 4 and 1 (each within the scatter of the next).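

In this assay, placing isopropoxy on this aromatic carbon, ortho to a chloro group, instead of 3,5-dimethyl-1,2-oxazol-4-yl gives an 18-fold higher number from compound 2 to compound 4 (1.26 log units; beyond the scatter), a large step beyond the scatter. Compounds 1 and 3 also differ from compound 2 elsewhere on the shared core, whereas this pair changes in one place only, so the step can be tied directly to this exchange and shows that the number in this assay depends strongly on the group at this position. No measurement offered here accounts for the size of the step.

Going by these compounds alone, with only two groups compared on this otherwise identical core, it remains open whether the higher number goes with losing the five-membered aromatic ring, with the oxygen link, or with the particular shape of the isopropoxy group; a plain phenyl ring, a methoxy group or a dimethylamino group at the same carbon would help separate these possibilities. Going by these compounds, it is also open whether the exchange would give a step of similar size on a core carrying a fluoro or methyl group, as in compound 1 and compound 3.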